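The source may hold more compounds than are shown below. What is called first, only, known or untested is meant among the compounds shown, and "the series" means these compounds.

Of the compounds shown here, three built on one shared core have so far been measured in a functional assay on QGY7701 cells (Homo sapiens) for cytotoxicity, read by MTT assay, with a stated time of 48 h; a higher number here means a weaker inhibitor, a lower number a stronger inhibitor. Compound 1 `Cc1cccc(Cn2cc(COc3ccc4c(=O)ccoc4c3)nn2)c1` gives 22400 nM. Compound 3 `O=c1ccoc2cc(OCc3cn(Cc4cccc(Br)c4)nn3)ccc12` gives 17600 nM, and the step of a 1.3-fold lower number from compound 1 to compound 3 (0.10 log units; within the scatter) places the two alongside one another. Compound 2 `O=c1ccoc2cc(OCc3cn(Cc4ccc([N+](=O)[O-])cc4)nn3)ccc12` stands apart from both. In this assay compound 2 gives > 100000 nM, which is a limit of the assay and not a number, because the value sits at the limit of > 100000 nM in this assay, at which 1 of the 3 values shown sits. Measured from the two neighbours, the steps into and out of compound 2 are an at least 4.4-fold higher number from compound 1 to compound 2 (0.64 log units; beyond the scatter) and an at least 5.6-fold lower number from compound 2 to compound 3 (0.75 log units; beyond the scatter), so compound 2 is the weakest of the three on the numbers shown.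

Compound 4 `O=c1ccoc2cc(OCc3cn(Cc4ccccc4)nn3)ccc12` is the next to be measured. It differs from compound 2 in one place: hydrogen in place of nitro on an aromatic carbon. The nitro leaves and a hydrogen enters, on an aromatic carbon of a six-membered aromatic ring of carbon only. The two steps that bear on this are the ones that lead away from compound 2 towards compound 1 and compound 3, each at least modest and beyond the scatter; compound 4 carries neither methyl nor bromo, so the change is read as leaving the weak end. The step of an at least 4.0-fold lower number from compound 2 to compound 4 (0.60 log units; beyond the scatter) is therefore expected to be a fall beyond the scatter. For compound 4 the estimate in this assay is 25000 nM, expected to lie between 12000 nM and 60000 nM.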

Compound 4, half-maximal inhibitory concentration: > 100000 nM
Compound 4 ended at the assay's limit (the forecaster's own chance of this, stated with the estimate: 15%); middle value at least 4.0-fold (0.60 log units) from the limit.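

In this assay compound 4 gives > 100000 nM, which is a limit of the assay and not a number. The step between compound 2 and compound 4 cannot be read, so taking away the nitro to leave a plain phenyl brought no measured value, and the weak end of the set is now shared: the limit of > 100000 nM in this assay, at which 2 of the 4 values shown sit. What the earlier compounds could not show is how much the methyl and the bromo count, for hydrogen in place of methyl gives an at least 4.4-fold higher number from compound 1 to compound 4 (0.64 log units; beyond the scatter), and hydrogen in place of bromo gives an at least 5.6-fold higher number from compound 3 to compound 4 (0.75 log units; beyond the scatter), so among these compounds a measured value goes with those two groups, while compound 2 goes against any reading that every group on this ring would serve.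

From the compounds shown here alone, the order of compound 2 and compound 4 stays open. Also open, going by these compounds, is whether a measured value is particular to methyl and bromo or would also come with a chloro, a methoxy or an amine on the same ring.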